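The source may hold more compounds than are shown below. What is called first, only, known or untested is meant among the compounds shown, and "the series" means these compounds.

Of the compounds shown here, two built on a shared core have been tested in a functional assay on SMMC-7721 cells (Homo sapiens) for cytotoxicity, read by MTT assay, with a stated time of 72 h; on this read-out higher numbers stand for weaker inhibition and lower numbers for stronger inhibition. Compound 1 `CCNC(=O)N1CCN(C(=S)SCc2cn(Cc3ccccc3F)nn2)CC1` already carries the ethylcarbamoyl group. In this assay compound 1 gives > 128000 nM, which is a limit of the assay and not a number. Compound 2 `NC(=O)N1CCN(C(=S)SCc2cn(Cc3ccc(Cl)cc3)nn2)CC1` carries the plain carbamoyl group together with the benzyl substituent that compound 3 shares. In this assay compound 2 gives > 128000 nM, again a limit rather than a measured number. Where compound 2 stands is therefore known only as the limit of > 128000 nM in this assay, at which 2 of the 2 values shown sit.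

Compound 3 `CCNC(=O)N1CCN(C(=S)SCc2cn(Cc3ccc(Cl)cc3)nn2)CC1` differs from compound 2 in one place: ethyl in place of hydrogen on an amide-type nitrogen. Among the compounds with values here, no step between two measured compounds is available to size this change. The step from compound 2 to compound 3 is expected to be a step that the limit leaves unreadable from compound 2 to compound 3, nothing beyond the scatter, because compound 1 with > 128000 nM already shows the ethyl group leaving the read-out at a limit. Compound 3 is expected to give 160000 nM, with a range from 60000 nM to 600000 nM, and most likely to be reported only as a limit.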

Compound 3, half-maximal inhibitory concentration: > 128000 nM
Compound 3 gave a limit, no number; the forecaster's own chance of this, stated with the estimate: 85%; the middle value does not contradict the limit.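

Within the data shown here, compound 1, compound 2 and compound 3 all stop at a limit of the assay, so no step to compound 3 from compound 2 or compound 1 can be read. Left open is how strongly any of them inhibits in this assay and what the ethyl or 4-chlorophenyl change does there. All three share one reading: the limit of > 128000 nM in this assay, at which 3 of the 3 values shown sit.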